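Two limits and a fluorine swap on the aryl group

This account rests on a few compounds, and the source may have more. Where it says the series, first, only, none or still open, it means among the compounds named here.

Measured in a functional assay on A549 cells (Homo sapiens) for antiproliferative activity, read by MTT assay, with a stated time of 48 h; a lower number here means a stronger inhibitor, a higher number a weaker inhibitor:
- compound 1 `C/C(=C\CC/C(C)=C/CC[C@@H]1[C@@]2(C)CCC(=O)C(C)(C)[C@H]2CC[C@@]1(C)O)CC/C=C(\C)C(=O)OCc1cn(-c2ccccc2)nn1`: > 150000 nM (a limit)
- compound 2 `C/C(=C\CC/C(C)=C/CC[C@@H]1[C@@]2(C)CCC(=O)C(C)(C)[C@H]2CC[C@@]1(C)O)CC/C=C(\C)C(=O)OCc1cn(-c2ccc(C)cc2)nn1`: > 150000 nM (a limit)

Compound 2 gives > 150000 nM, which is a limit of the assay and not a number. Going by the values given here, it has no readable position of its own, and the same holds for the only other measured compound: the limit of > 150000 nM in this assay, at which 2 of the 2 values shown sit.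

Compound 3 `C/C(=C\CC/C(C)=C/CC[C@@H]1[C@@]2(C)CCC(=O)C(C)(C)[C@H]2CC[C@@]1(C)O)CC/C=C(\C)C(=O)OCc1cn(-c2ccccc2F)nn1` carries 2-fluorophenyl in place of 4-methylphenyl on an aromatic nitrogen of the five-membered aromatic ring with 3 nitrogen, and the shared core is unchanged: 2-fluorophenyl in place of 4-methylphenyl on an aromatic nitrogen.

Among the compounds with values here, only one measured step bears on this change, and it touches the same aryl group: a step that the two limits leave unreadable from compound 1 to compound 2. That step is methyl in place of hydrogen on an aromatic carbon, and it has no readable size. The data therefore give no size or direction for a change in this assay, and no step beyond the scatter is expected. A further limit is the likeliest report.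

For compound 3 the estimated value is 150000 nM, with an expected range of 60000 nM to 400000 nM.

The step this estimate means is expected to be a number no higher from compound 2 to compound 3 (the limit leaves the size open).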

Compound 3, half-maximal inhibitory concentration: > 150000 nM
Compound 3 gave a limit, no number; the forecaster's own chance of this, stated with the estimate: 75%; the middle value lies on the limit itself.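

In this assay compound 3 gives > 150000 nM, which is a limit and not a number. No step among compound 1, compound 2 and compound 3 can be read, and all three sit at the same limit: the limit of > 150000 nM in this assay, at which 3 of the 3 values shown sit.

The compounds shown leave open whether any other aryl group on that aromatic nitrogen would give a readable value.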